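Swapping Halogens on the Aryl Group of Compound 3

This account rests on a few compounds, and the source may have more. Where it says the series, first, only, none or still open, it means among the compounds named here.

Measured in a functional assay on SGC-7901 cells (Homo sapiens) for antiproliferative activity, read by MTT assay, with a stated time of 24 h; on this read-out higher numbers stand for weaker inhibition and lower numbers for stronger inhibition:
Compound 1 `Cc1ccccc1-n1cc(-c2cccc(NS(=O)(=O)c3c[nH]c(=O)[nH]c3=O)c2)nn1` gives 9230 nM.
Compound 2 `Cc1ccc(-n2cc(-c3cccc(NS(=O)(=O)c4c[nH]c(=O)[nH]c4=O)c3)nn2)cc1` gives 9430 nM.
Compound 3 `O=c1[nH]cc(S(=O)(=O)Nc2cccc(-c3cn(-c4ccc(F)cc4)nn3)c2)c(=O)[nH]1` reaches only the limit > 20000 nM, a limit of the assay rather than a number.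

Compound 3 is the weakest of the three, since an at least 2.1-fold higher number from compound 1 to compound 3 (0.33 log units; beyond the scatter) and an at least 2.1-fold higher number from compound 2 to compound 3 (0.32 log units; beyond the scatter) both lie beyond the scatter, while a 1.0-fold higher number from compound 1 to compound 2 (0.01 log units; within the scatter) stays within it. Compound 4 `O=c1[nH]cc(S(=O)(=O)Nc2cccc(-c3cn(-c4cccc(Cl)c4)nn3)c2)c(=O)[nH]1` differs from compound 3 by 3-chlorophenyl in place of 4-fluorophenyl on an aromatic nitrogen. Going by the values given here, no measured step trades one halogen for another; the closest guide is an at least 2.1-fold higher number from compound 2 to compound 3 (0.32 log units; beyond the scatter), where introducing a halogen on that aryl group weakened inhibition. The step to compound 4 is therefore expected to stay within the scatter, an at least 1.1-fold lower number from compound 3 to compound 4 (0.04 log units; that floor lies within the scatter). Compound 4 is estimated at 18000 nM, with a range of 8000 nM to 40000 nM.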

Compound 4, half-maximal inhibitory concentration: 3950 nM
Estimate against measurement, compound 4: 4.6-fold (0.66 log units) above; measured number outside the range, below it.
By their numbers in this assay, from the lowest: compound 4; then compounds 1 and 2 (each within the scatter of the next). At a limit, above all of these: compound 3.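

A halogen on the aryl group at this aromatic nitrogen need not weaken inhibition, as 3-chlorophenyl in place of 4-fluorophenyl gives an at least 5.0-fold lower number from compound 3 to compound 4 (0.70 log units; beyond the scatter). The 3-chlorophenyl group also improves on both methylphenyl groups, with a 2.4-fold lower number from compound 2 to compound 4 (0.38 log units; beyond the scatter) and a 2.3-fold lower number from compound 1 to compound 4 (0.37 log units; beyond the scatter). Compound 3 gives a limit rather than a number, and the step from it is only a floor: the limit of > 20000 nM in this assay, at which 1 of the 4 values shown sits.

Still open, as far as these compounds go, is whether the identity of the halogen or its place on the ring matters more, a question that 4-chlorophenyl and 3-fluorophenyl would help separate. Also open, from the compounds shown here alone, is how an amine or a carboxylic acid on this aryl group would fare.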